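This account rests on a few compounds, and the source may have more. Where it says the series, first, only, none or still open, it means among the compounds named here.

In a toxicity assay on MT4 cells (Homo sapiens) for cytotoxicity, read by MTT assay, with a stated time of 5 days (on this read-out higher numbers stand for lower toxicity in this test and lower numbers for higher toxicity in this test), compound 3 (`Cc1cc(-c2cc3ccccc3s2)cc(C)c1Nc1ccnc(Nc2ccc(C#N)cc2)n1`) stands highest of the three measured compounds at 138000 nM. Compound 2 (`Cc1cc(-c2cccs2)cc(C)c1Nc1ccnc(Nc2ccc(C#N)cc2)n1`) gives 10000 nM, and compound 1 (`Cc1cc(-c2ccco2)cc(C)c1Nc1ccnc(Nc2ccc(C#N)cc2)n1`) gives 1700 nM.

Compound 4 (`Cc1cc(-c2ccnc3ccccc23)cc(C)c1Nc1ccnc(Nc2ccc(C#N)cc2)n1`) brings a new change: quinolin-4-yl in place of 1-benzothiophen-2-yl on an aromatic carbon. It sits on an aromatic carbon, meta to two methyl groups and para to a large group.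

Three measured steps at this same place bear on it. The step of a 5.9-fold higher number from compound 1 to compound 2 (0.77 log units; beyond the scatter) was modest, while an 81-fold higher number from compound 1 to compound 3 (1.91 log units; beyond the scatter) and a 14-fold higher number from compound 2 to compound 3 (1.14 log units; beyond the scatter) were large. For the measured compounds named here, both large steps end at compound 3, the only measured compound with 1-benzothiophen-2-yl. Going by the values given here, no measured compound carries quinolin-4-yl, so the reading across is weak. Compound 3 at 138000 nM is taken as the high end of the series, and a step of modest size towards a lower number is expected in this assay.

The estimated change is a 5.5-fold lower number from compound 3 to compound 4 (0.74 log units; beyond the scatter). For compound 4 the expected value is 25000 nM, with an estimated range of 5000 nM to 120000 nM.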

Compound 4, half-maximal cytotoxic concentration: 3500 nM
Compound 4: the middle estimate sits 7.1-fold (0.85 log units) above what was measured; measured number below the stated range.
By their numbers in this assay, from the lowest: compound 1; then compound 4; then compound 2; then compound 3.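

In this assay, two aromatic rings in the group on this carbon do not by themselves give a high number, since 1-benzothiophen-2-yl and quinolin-4-yl both carry two and yet the change between them gives a 39-fold lower number from compound 3 to compound 4 (1.60 log units; beyond the scatter). Compound 4 instead falls among the single-ring groups, with a 2.9-fold lower number from compound 2 to compound 4 (0.46 log units; beyond the scatter) and a 2.1-fold higher number from compound 1 to compound 4 (0.31 log units; beyond the scatter), so the high number of compound 3 remains specific to 1-benzothiophen-2-yl among the groups shown. No measurement at hand accounts for this difference.

The change from 1-benzothiophen-2-yl to quinolin-4-yl alters the hetero atom, a ring size and the point of attachment together, and these compounds cannot separate them. Also open, from the compounds shown here alone, is where an unsubstituted phenyl, a morpholin-4-yl or a carboxylic acid on this carbon would fall in the order.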